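Aryl sulfone variation in a shared-core series

The source may hold more compounds than are shown below. What is called first, only, known or untested is meant among the compounds shown, and "the series" means these compounds.

Measured compounds:
compound 1, `COc1ccc(S(=O)(=O)c2cnc3ccc(C)cc3c2N2CCC(C)CC2)cc1`: 62%
compound 2, `Cc1ccc2ncc(S(=O)(=O)c3cccc(C#N)c3)c(N3CCC(C)CC3)c2c1`: 52%

In an assay on isolated protein for displacement of a labelled ligand from metabotropic glutamate receptor 5 (Homo sapiens), with a stated time of 60 min, tested at 1 uM (on this read-out lower numbers stand for less inhibition and higher numbers for more inhibition at the one concentration tested (going by the name of the read-out)), compound 1 gives 62% and compound 2 gives 52%. Compound 2 stands lowest of the two numbers, but a number 10 percentage points lower from compound 1 to compound 2 (within the scatter) lies within the scatter, so the two compounds cannot be ordered on these data.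

Compound 3, `Cc1ccc2ncc(S(=O)(=O)c3ccc(C)c(C)c3)c(N3CCC(C)CC3)c2c1`, is not yet measured. Its change from compound 2 is 3,4-dimethylphenyl in place of 3-cyanophenyl on a sulfonyl sulfur. Within the data shown here, the one measured step, a number 10 percentage points lower from compound 1 to compound 2 (within the scatter), also exchanged the aryl group on the sulfonyl sulfur and stayed within the scatter; that is the only evidence bearing on this change, and no measured step replaces the 3-cyanophenyl by a group with no hydrogen-bond acceptor. The expectation is therefore a step no larger than the scatter, a number 3 percentage points higher from compound 2 to compound 3 (within the scatter). Compound 3 is estimated at 55%, with a range from 35% to 75%.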

Compound 3, a percentage reported as inhibition, at one concentration (the size of the read-out at that concentration, not a potency): 90%
The estimate for compound 3 lay 35 percentage points below the measured number; measured number above the stated range.
By their numbers in this assay, from the lowest: compounds 2 and 1 (each within the scatter of the next); then compound 3.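

In this assay the aryl group on the sulfonyl sulfur proves able to move the number well beyond the scatter: 3,4-dimethylphenyl in place of 3-cyanophenyl gives a number 38 percentage points higher from compound 2 to compound 3 (beyond the scatter) and in place of 4-methoxyphenyl gives a number 28 percentage points higher from compound 1 to compound 3 (beyond the scatter) on the same shared core. The earlier pair gave no sign of this, and compound 3 now stands apart from both, with an entering group that has no hydrogen-bond acceptor where the 3-cyanophenyl has one. No measurement at hand accounts for the size of these steps.

Open, as far as these compounds go, is whether both methyl groups are needed, or whether a 3-methylphenyl or a 4-methylphenyl alone would stand with compound 3. Also open, from the compounds shown here alone, is whether a chlorophenyl or a plain phenyl on the sulfonyl sulfur would keep the gain.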